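Trifluoromethyl for ethoxycarbonyl on the aryl urea

The compounds below may be only part of what the source reports. "The series", "measured", "known", "first", "only" and "open" are said of these compounds alone.

Compound 1 `CCOC(=O)c1ccc(NC(=O)N2CC2C#N)cc1` gives 3300 nM in a functional assay on MCF7 cells (Homo sapiens) for inhibition; on this read-out higher numbers stand for weaker inhibition and lower numbers for stronger inhibition.
Compound 2 `N#CC1CN1C(N)=O` gives > 54000 nM in this assay, a limit of the assay rather than a number.
Compound 3 `N#CC1CN1C(=O)Nc1cccc2ccccc12` gives 2000 nM in this assay.

Of the two compounds with a number in this assay, compound 1 has the higher one, and the nearest to it is compound 3, whose number sits lower by a gap that falls within the usual scatter of repeated measurements, so no order between compound 1 and compound 3 can be read from these two values. The value of compound 2 is a limit only, as noted in the limit of > 54000 nM in this assay, at which 1 of the 3 values shown sits.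

Compound 4 `N#CC1CN1C(=O)Nc1ccc(C(F)(F)F)cc1` is the next compound to be measured in this assay. It differs from compound 1 by a single change on the aromatic ring: trifluoromethyl in place of ethoxycarbonyl on an aromatic carbon. Within the data shown here, no measured pair in this set shows such a change, so there is no measured step to lean on here. Compound 4 is therefore expected to stay close to compound 1, with the step from compound 1 to compound 4 estimated at a 1.2-fold higher number from compound 1 to compound 4 (0.08 log units; within the scatter), which is no more than the scatter in either direction. On that basis compound 4 is estimated at 4000 nM in this assay, within a range from 1500 nM to 11000 nM.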

Compound 4, half-maximal inhibitory concentration: 1300 nM
Compound 4: the middle estimate sits 3.1-fold (0.49 log units) above what was measured, and the stated range ends above it.
By their numbers in this assay, from the lowest: compounds 4, 3 and 1 (each within the scatter of the next, the first and the last beyond it). At a limit, above all of these: compound 2.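

Trifluoromethyl in place of ethoxycarbonyl on this aromatic carbon, para to a group of 8 heavy atoms, gives a 2.5-fold lower number from compound 1 to compound 4 (0.40 log units; beyond the scatter) in this assay. Among these compounds, this is the first step in the set that can be read, and it shows that the number at this position responds to the group placed there by more than the scatter. Trifluoromethyl carries 0 hydrogen-bond acceptors and the number still falls, so the hydrogen-bond acceptors of ethoxycarbonyl are not needed to reach this level, though no measured property here accounts for the size of the step.

A single exchange cannot separate the loss of ethoxycarbonyl from the arrival of trifluoromethyl, and a methyl group, a chlorine atom, an amine or a carboxylic acid on this same aromatic carbon would help tell the two apart. Going by these compounds, whether the same exchange would give a step of similar size on a different core also remains open.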